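Pentyloxy for Propylamino at the Limit of Cytotoxicity

This account rests on a few compounds, and the source may have more. Where it says the series, first, only, none or still open, it means among the compounds named here.

Values so far in an ADME assay on BCBL1 cells (Homo sapiens) for cytotoxicity, with a stated time of 7 days (a lower number here means that less compound is tolerated, a higher number that more compound is tolerated), are all limits and not numbers:
- Compound 1 `COCCOc1nc(N)nc2c1ncn2/C=C1/CC1(CO)CO` gives > 20000 nM as a limit
- Compound 2 `Nc1nc(OCc2ccccc2)c2ncn(/C=C3/CC3(CO)CO)c2n1` gives > 20000 nM as a limit
- Compound 3 `CCCNc1nc(N)nc2c1ncn2/C=C1/CC1(CO)CO` gives > 20000 nM as a limit

Compound 3 gives only a limit (> 20000 nM) and no number. The evidence for the series is the limit of > 20000 nM in this assay, at which 3 of the 3 values shown sit, and so the three compounds cannot be ranked against each other.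

Compound 4 `CCCCCOc1nc(N)nc2c1ncn2/C=C1/CC1(CO)CO` carries pentyloxy in place of propylamino on an aromatic carbon. For the measured compounds named here, three measured steps bear on this change. Two of them exchange propylamino for another group on an aromatic carbon, and these are a step that the two limits leave unreadable from compound 1 to compound 3 and a step that the two limits leave unreadable from compound 2 to compound 3. The third is a step that the two limits leave unreadable from compound 1 to compound 2 and it changes the chain of an oxygen-linked group. None of the three has a readable size, so they offer no measured shift to carry over. Compound 1 and compound 2 both hold an oxygen-linked group on the shared core and both sit at the limit, so no step beyond the scatter is expected in this assay and no direction can be foreseen. The estimated change is a number no higher from compound 3 to compound 4 (the limit leaves the size open) in size. Compound 4 is expected at 20000 nM (estimated range 10000 nM to 30000 nM).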

Compound 4, half-maximal cytotoxic concentration: > 20000 nM
Compound 4: no number, only a limit; the forecaster's own chance of this, stated with the estimate: 75%; the middle value lies on the limit itself.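

In this assay compound 4 gives > 20000 nM, which is a limit and not a number. Its steps to compound 1, compound 2 and compound 3 cannot be read, and the four compounds cannot be ranked: the limit of > 20000 nM in this assay, at which 4 of the 4 values shown sit. The compounds shown leave open whether swapping the group on the aromatic carbon changes cytotoxicity at all.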